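Methyl to Nitro on the Phenyl Ring: Oral Activity

The source may report more compounds than this note shows. Statements on the series, on what has been measured and on what is new or still open speak of the compounds shown alone.

Measured compounds:
compound 1 `O=C1NC(=O)/C(=C/c2ccc(OCCSc3nnc(-c4ccccc4)[nH]3)cc2)S1` — 18.6%
compound 2 `Cc1ccc(-c2nnc(SCCOc3ccc(/C=C4\SC(=O)NC4=O)cc3)[nH]2)cc1` — 25.2%

In a functional assay on the whole organism (strain Wistar) with Rattus norvegicus as the target, with a stated time of 15 days, at a dose of 3 mg/kg by the oral route (a higher number here means a stronger effect of the compound at the dose given, a lower number a weaker effect), compound 1 gives 18.6%, and compound 2 gives 25.2%. For the measured compounds named here, on the two numbers known, compound 2 stands at the larger figure, but the step of a number 6.6 percentage points higher from compound 1 to compound 2 (within the scatter) lies within the scatter, so the two compounds are not separated by this assay.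

Compound 3 `O=C1NC(=O)/C(=C/c2ccc(OCCSc3nnc(-c4ccc([N+](=O)[O-])cc4)[nH]3)cc2)S1` is not yet measured. It differs from compound 2 by nitro in place of methyl on an aromatic carbon. Going by the values given here, the only measured step, a number 6.6 percentage points higher from compound 1 to compound 2 (within the scatter), touches the same aromatic carbon, and it stayed within the scatter. Nothing measured here shows what a nitro at this place does, so the step of a number 1.2 percentage points lower from compound 2 to compound 3 (within the scatter) is expected to remain within the scatter. Compound 3 is therefore estimated to give 24% in this assay, within a range from 10% to 40%.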

Compound 3, a percentage reported as activity, at one dose (the size of the read-out at that dose, not a potency): 14.1%
For compound 3 the middle estimate is 9.9 percentage points above the measured one; low and high end bracket the measured number.
By their numbers in this assay, from the lowest: compounds 3, 1 and 2 (each within the scatter of the next, the first and the last beyond it).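

In this assay, for the compounds shown here, the change from 4-methylphenyl to 4-nitrophenyl shows for the first time that this aromatic carbon can separate two compounds, with a number 11.1 percentage points lower from compound 2 to compound 3 (beyond the scatter) for nitro in place of methyl. The separation holds only for that pair: with hydrogen as the reference, the nitro group gives a number 4.5 percentage points lower from compound 1 to compound 3 (within the scatter) and compound 1 remains within the scatter of both substituted compounds, so neither group can be said to change the read-out relative to hydrogen. No measurement here gives a reason for the gap between the methyl and nitro compounds.

The compounds shown leave open whether this gap extends to other groups at the same carbon, such as an amine, a methoxy group or a carboxylic acid. They also leave open whether a longer chain in place of the methyl group would move the read-out beyond the scatter of compound 1.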